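Iodo for chloro on the halophenyl ring of compound 2

The source may hold more compounds than are shown below. What is called first, only, known or untested is meant among the compounds shown, and "the series" means these compounds.

Two hydrazones built on the same chlorinated bicyclic core have been measured so far. Compound 1 `Cc1ccc(/C=N\NC(=O)C2=C(Cl)c3ccccc3CCC2)cc1` gives 2300 nM in a functional assay on HeLa cells (Homo sapiens) for inhibition, read by sulforhodamine B assay, with a stated time of 48 h; a higher number here means a weaker inhibitor of growth, a lower number a stronger inhibitor of growth. Compound 2 `O=C(N/N=C/C1=C(Cl)c2ccccc2CCC1)c1cccc(Cl)c1` gives 19200 nM in this assay, the highest of the two numbers, and it sits well above compound 1, beyond the scatter. The two compounds differ in more than one place, so no single change can be read from that pair.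

Compound 3 `O=C(N/N=C/C1=C(Cl)c2ccccc2CCC1)c1cccc(I)c1` has not yet been measured. It differs from compound 2 by one exchange: iodo in place of chloro on an aromatic carbon, that is, 3-chlorophenyl becomes 3-iodophenyl, with no ring, donor, acceptor or charge added or lost. Within the data shown here, no measured pair in this set isolates this exchange, so its effect is unknown. The author expects a small step, likely toward a lower number but possibly within the scatter, as a 1.6-fold lower number from compound 2 to compound 3 (0.20 log units; within the scatter). Compound 3 is therefore estimated at 12000 nM in this assay, with a range from 4000 nM to 40000 nM.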

Compound 3, concentration for 50% growth inhibition: 6300 nM
Beside the measured number, compound 3's estimate is 1.9-fold (0.28 log units) above it; the range from low to high includes it.
By their numbers in this assay, from the lowest: compound 1; then compound 3; then compound 2.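

In this assay, the exchange of 3-chlorophenyl for 3-iodophenyl gives a 3.0-fold lower number from compound 2 to compound 3 (0.48 log units; beyond the scatter), a step beyond the scatter. Among these compounds, this is the first change in the set that can be read at a single place, since compound 1 differs from the other two compounds in more than one place. It shows that this aromatic carbon, meta to a large group, is sensitive to the identity of the halogen alone, as the exchange of one heavy atom for another adds or removes no ring, donor, acceptor or charge, though nothing shown here bears on why the number falls.

With only chloro and iodo at this place, the compounds shown leave open whether the number follows the halogen in a steady way, as fluoro and bromo would test, or whether a non-halogen group such as methoxy, an amine or a carboxylic acid would be tolerated there. They also leave open whether the same iodo for chloro exchange would give a step of similar size on a different core or at another carbon of this phenyl ring.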